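Swapping Naphthalen-1-yl for 4-Fluorophenyl on a Shared Core

The source may hold more compounds than are shown below. What is called first, only, known or untested is meant among the compounds shown, and "the series" means these compounds.

Compound 1, `Brc1cn2ccnc2c(-c2ccc3ncn(C4CCCCC4)c3c2)n1`: 6.47%
Compound 2, `c1ccc2c(-c3cn4ccnc4c(-c4ccc5ncn(C6CCCCC6)c5c4)n3)cccc2c1`: 11.7%

Of the compounds shown here, two have been tested in a functional assay on SN12C cells (Homo sapiens) for inhibition, read by sulforhodamine B assay, with a stated time of 48 h, tested at 10 uM; a higher number here means more inhibition at the concentration tested (going by the name of the read-out), a lower number less inhibition. Compound 1 gives 6.47%, and compound 2 gives 11.7%. Within the data shown here, compound 2 holds the higher of the two numbers, but the only step measured so far, a number 5.2 percentage points higher from compound 1 to compound 2 (within the scatter), lies within the scatter, so the two compounds cannot truly be told apart on this read-out.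

Compound 3, `Fc1ccc(-c2cn3ccnc3c(-c3ccc4ncn(C5CCCCC5)c4c3)n2)cc1`, differs from compound 2 in one place: 4-fluorophenyl in place of naphthalen-1-yl on an aromatic carbon. Among the measured compounds shown here, the single measured step bears on this change only loosely, since it exchanged bromo for naphthalen-1-yl, whereas here one aromatic group replaces another. That step was small, so no step beyond the scatter is expected here either; the estimated step is a number 2.7 percentage points lower from compound 2 to compound 3 (within the scatter). Compound 3 is therefore expected to give about 9%, within a range from -2% to 20%.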

Compound 3, a percentage reported as inhibition, at one concentration (the size of the read-out at that concentration, not a potency): 3.97%
Compound 3: the middle estimate sits 5 percentage points above what was measured; the measured number falls inside the stated range.
By their numbers in this assay, from the lowest: compounds 3, 1 and 2 (each within the scatter of the next).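

In this assay, putting 4-fluorophenyl, with one aromatic ring, in place of naphthalen-1-yl, with two, gives a number 7.7 percentage points lower from compound 2 to compound 3 (within the scatter) on this aromatic carbon next to the ring nitrogen. Putting 4-fluorophenyl in place of bromo at the same carbon gives a number 2.5 percentage points lower from compound 1 to compound 3 (within the scatter) and adds a second aryl comparison, so bromo, 4-fluorophenyl and naphthalen-1-yl cannot be told apart on this read-out, whichever pair is taken. No measured information is available to explain why these three groups cannot be separated here.

Whether any group at this carbon can move the number beyond the scatter remains open, since all three compounds shown carry either a halogen or a plain aromatic ring there. An amine or a carboxylic acid at this carbon would test that question with a group of a different kind.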